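Chloro at the ring carbon where trifluoromethyl once raised the number

The source may hold more compounds than are shown below. What is called first, only, known or untested is meant among the compounds shown, and "the series" means these compounds.

Within the data shown here, compound 3 (`COc1ccccc1NC(=O)COc1cc(C)nc2ccccc12`) is the only member of this small set with an actual number in an ADME assay on HepG2 cells (Homo sapiens) for cytotoxicity, read by trypan blue exclusion, with a stated time of 48 h, in the presence of a further agent that is not named here (on this read-out lower numbers stand for higher toxicity in this test and higher numbers for lower toxicity in this test), where compound 3 gives 43900 nM. Compound 1 (`COc1ccccc1NC(=O)COc1cc(C)nc2ccc(C(F)(F)F)cc12`) gives only a limit in this assay, namely > 128000 nM. Compound 2 (`COc1ccc(NC(=O)COc2cc(C)nc3ccc(OC)cc23)cc1`) likewise gives only a limit in this assay, namely > 142000 nM. Among the measured compounds shown here, compound 3 therefore stands alone as the one compound with a measurable number, and the two limits sit above it.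

Compound 4 (`COc1ccccc1NC(=O)COc1cc(C)nc2ccc(Cl)cc12`) differs from compound 3 by chloro in place of hydrogen on an aromatic carbon. For the measured compounds named here, the one measured step that bears on this place is an at least 2.9-fold lower number from compound 1 to compound 3 (0.46 log units; beyond the scatter), which shows that removing the trifluoromethyl from that ring carbon lowered the number to the point where compound 3 gave 43900 nM. Compound 1, for its part, stayed at a limit of the assay (the limit of > 128000 nM in this assay, at which 1 of the 3 values shown sits). Putting a chloro onto the same carbon is expected to move the number back up, in the direction of the limit, by roughly the size seen there. Compound 4 is therefore estimated to give about 100000 nM in this assay, with a range from 40000 nM to 250000 nM. That estimate corresponds to an expected step of a 2.3-fold higher number from compound 3 to compound 4 (0.36 log units; beyond the scatter), and a fair chance that only a limit is reported.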

Compound 4, half-maximal cytotoxic concentration: 140000 nM
The estimate for compound 4 lay 1.4-fold (0.15 log units) below the measured number; the range from low to high includes it.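

In this assay, among these compounds, a single chlorine on this aromatic carbon gives a 3.2-fold higher number from compound 3 to compound 4 (0.50 log units; beyond the scatter), which shows that trifluoromethyl is not the only group here linked to a higher number, meaning lower toxicity in this test. The earlier step at this carbon ended at a limit, so its full size stayed hidden, whereas this step runs between two actual numbers and its size can be read directly. The step between compound 1 and compound 4 cannot be read, because compound 1 gives only a limit and not a number: the limit of > 128000 nM in this assay, at which 1 of the 4 values shown sits.

The compounds shown do not tell whether an amine or a carboxylic acid on this same carbon would also go with a higher number than hydrogen, or whether any group placed here would do so. Compound 2 differs from compound 3 in more than one place, so it cannot show whether chloro would give a similar step on a core carrying a methoxy group elsewhere.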